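Swapping the Side Chain: Toxicity Expected for Compound 4

This account rests on a few compounds, and the source may have more. Where it says the series, first, only, none or still open, it means among the compounds named here.

Compound 1 `O=C1O[C@@H](CN2CCC(O)CC2)CN1c1ccc(-n2cc(-c3ccccn3)cn2)c(F)c1`: in an ADME assay on HEK293-A cells (Homo sapiens) for cytotoxicity, read by MTT assay, with a stated time of 48 h (on this read-out higher numbers stand for weaker inhibition and lower numbers for stronger inhibition), compound 1 reaches only the assay limit, > 400 ug/mL.
Compound 2 `CC(=O)OC[C@H]1CN(c2ccc(-n3cc(-c4ccccn4)cn3)c(F)c2)C(=O)O1`: compound 2 likewise sits at the limit, > 400 ug/mL.
Compound 3 `CCC(=O)NC[C@H]1CN(c2ccc(-n3cc(-c4ccccn4)cn3)c(F)c2)C(=O)O1`: compound 3 gives a real number, 389 ug/mL.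

Going by the values given here, compound 3 thus holds the only actual number among the three; the other two values are limits of the assay rather than numbers, as the shared limit shows (the limit of > 400 ug/mL in this assay, at which 2 of the 3 values shown sit). The step that the two limits leave unreadable from compound 1 to compound 2 cannot be read because both values are limits. The steps of an at least 1.0-fold lower number from compound 1 to compound 3 (0.01 log units; that floor lies within the scatter) and an at least 1.0-fold lower number from compound 2 to compound 3 (0.01 log units; that floor lies within the scatter) are floors that lie within the scatter, so none of the three compounds can be told apart in this assay.

Compound 4 `NC(=O)[C@H]1CN(c2ccc(-n3cc(-c4ccccn4)cn3)c(F)c2)C(=O)O1` differs from compound 3 by carbamoyl in place of (propanoylamino)methyl on a saturated ring carbon. The two readable steps also exchanged the side chain on the shared core and brought no change beyond the scatter, so compound 4 is expected to show no step beyond the scatter, a 1.0-fold higher number from compound 3 to compound 4 (0.01 log units; within the scatter). Compound 4 is therefore estimated at 400 ug/mL, with a range from 200 ug/mL to 800 ug/mL, and a real chance that only a limit is again reported.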

Compound 4, half-maximal inhibitory concentration: 152 ug/mL
Estimate against measurement, compound 4: 2.6-fold (0.42 log units) above; measured number below the stated range.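

In this assay, going by these compounds alone, the group on this saturated ring carbon turns out to matter: carbamoyl in place of (propanoylamino)methyl gives a 2.6-fold lower number from compound 3 to compound 4 (0.41 log units; beyond the scatter), a shift towards stronger inhibition that no earlier step showed. Carbamoyl also stands apart from the other two side chains, with an at least 2.6-fold lower number from compound 2 to compound 4 (0.42 log units; beyond the scatter) and an at least 2.6-fold lower number from compound 1 to compound 4 (0.42 log units; beyond the scatter). These two sizes are only floors, because compound 1 and compound 2 each carry a limit rather than a number: the limit of > 400 ug/mL in this assay, at which 2 of the 4 values shown sit.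

The compounds shown leave open whether the shift belongs to the shorter group or to the carbonyl standing directly on the ring, since both change together from compound 3 to compound 4. A carboxylic acid, a methyl ester or an aminomethyl group on the same ring carbon would help to separate these two readings.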